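A Rearranged Group on the Sulfonyl Sulfur

The source may report more compounds than this note shows. Statements on the series, on what has been measured and on what is new or still open speak of the compounds shown alone.

Compounds measured so far in an ADME assay on the whole organism (plasma, Rattus norvegicus, strain Sprague-Dawley) for pharmacokinetics, read by LC-MS, using cassette dosing, at a dose of 0.2 mg/kg by the intravenous route; a higher number here means more compound in the circulation at the dose given, a lower number less compound in the circulation:
- compound 1 `CNCc1cn(S(=O)(=O)c2ccoc2)c(-c2cccnc2F)c1F`: 41 ng.h/mL
- compound 2 `CNCc1cn(S(=O)(=O)c2ccccn2)c(-c2cccnc2F)c1F`: 33 ng.h/mL
- compound 3 `CNCc1cn(S(=O)(=O)c2cccc(C)n2)c(-c2cccnc2F)c1F`: 41 ng.h/mL

These three compounds share a core and differ only in the group on the sulfonyl sulfur. In this assay compound 3 gives 41 ng.h/mL, level with compound 1 at the digits shown, and compound 2 lies within the scatter of both.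

The next compound is compound 4 `CNCc1cn(S(=O)(=O)c2cccnc2C)c(-c2cccnc2F)c1F`, which carries 2-methylpyridin-3-yl in place of 6-methylpyridin-2-yl on a sulfonyl sulfur. The two have the same atoms, joined differently. For the measured compounds named here, no measured compound carries this exact group, so the nearest guide is what earlier changes at this place did. Going by the values given here, three steps bear on it: a 1.2-fold lower number from compound 1 to compound 2 (0.09 log units; within the scatter), no change at the digits printed from compound 1 to compound 3 (within the scatter) and a 1.2-fold higher number from compound 2 to compound 3 (0.09 log units; within the scatter). None of the three compounds goes against this flat picture, though three compounds are a small sample.

A step beyond the scatter is therefore not expected, and the estimated step is a 1.0-fold lower number from compound 3 to compound 4 (0.01 log units; within the scatter). For compound 4 the expected value is 40 ng.h/mL, with an estimated range from 20 ng.h/mL to 80 ng.h/mL.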

Compound 4, area under the concentration-time curve: 32 ng.h/mL
Beside the measured number, compound 4's estimate is 1.3-fold (0.10 log units) above it; the range from low to high includes it.
By their numbers in this assay, from the lowest: compounds 4, 2, 1 and 3 (each within the scatter of the next).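

In this assay, joining the same atoms differently, as 2-methylpyridin-3-yl in place of 6-methylpyridin-2-yl on the sulfonyl sulfur, gives a 1.3-fold lower number from compound 3 to compound 4 (0.11 log units; within the scatter), so at this position the arrangement of the ring and its methyl group does not produce a step that can be told from the scatter. The new group also stays within the scatter of the other two groups, with a 1.0-fold lower number from compound 2 to compound 4 (0.01 log units; within the scatter) and a 1.3-fold lower number from compound 1 to compound 4 (0.11 log units; within the scatter), which means that all four compounds form one flat set and none of them goes against it. Nothing measured here explains why the number stays this flat across these groups.

Going by these compounds, all four groups on the sulfonyl sulfur are aromatic rings of similar size, so it remains open whether a different kind of group, such as a saturated cyclohexyl ring or a ring carrying an amine or a carboxylic acid, would stay within this flat set or break out of it. The rest of the shared core is the same in all four compounds, so the picture also says nothing about whether this position would stay as flat with a change elsewhere in the molecule.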